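Swapping the aniline ring on a shared quinazoline-free described core

This account rests on a few compounds, and the source may have more. Where it says the series, first, only, none or still open, it means among the compounds named here.

Of the compounds shown here, three share one core and have been tested in a functional assay on NCI-H1975 cells (Homo sapiens) for inhibition, read by MTT assay, with a stated time of 72 h; on this read-out higher numbers stand for weaker inhibition and lower numbers for stronger inhibition. Compound 1 `O=C(CSc1nc(Nc2ccccc2)c2ccccc2n1)Nc1cccc(Br)c1` gives 10100 nM; compound 2 `O=C(CSc1nc(Nc2ccccc2)c2ccccc2n1)Nc1cccc([N+](=O)[O-])c1` gives 17900 nM; compound 3 `C=CC(=O)Nc1cccc(NC(=O)CSc2nc(Nc3ccccc3Br)c3ccccc3n2)c1` gives 19300 nM. Among the measured compounds shown here, the only single-point step among them, a 1.8-fold higher number from compound 1 to compound 2 (0.25 log units; within the scatter), shows that exchanging one group on the amide-bearing ring leaves the number essentially where it was. Compound 3 has the highest of the three numbers, yet its gap to compound 2 and to compound 1 each lies within the scatter, so no order can be claimed among them.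

Compound 4 `C=CC(=O)Nc1cccc(NC(=O)CSc2nc(Nc3cc(OC)c(OC)c(OC)c3)c3ccccc3n2)c1` differs from compound 3 in one place: 3,4,5-trimethoxyphenyl in place of 2-bromophenyl on a nitrogen on an aromatic ring. For the measured compounds named here, no measured step touches this particular position, so the single step between compound 1 and compound 2 can only suggest that changes at the edges of this core have so far moved the number little. The expectation for compound 4 is therefore a step of a 1.2-fold lower number from compound 3 to compound 4 (0.08 log units; within the scatter) in this assay, not beyond the scatter. Compound 4 is estimated at 16000 nM, with a range from 5000 nM to 50000 nM.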

Compound 4, half-maximal inhibitory concentration: > 50000 nM
Compound 4: a limit, no number; the forecaster's own chance of this, stated with the estimate: 20%; at least 3.1-fold (0.49 log units) between middle value and limit.
By their numbers in this assay, from the lowest: compounds 1, 2 and 3 (each within the scatter of the next). At a limit, above all of these: compound 4.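

Swapping the group on the nitrogen on the aromatic ring, with 3,4,5-trimethoxyphenyl in place of 2-bromophenyl, gives an at least 2.5-fold higher number from compound 3 to compound 4 (0.41 log units; beyond the scatter) in this assay, the first step here that lies beyond the scatter. Among the compounds shown here, compound 4 gives > 50000 nM, which is a limit of the assay and not a number, and it is the only compound at that limit: the limit of > 50000 nM in this assay, at which 1 of the 4 values shown sits. The earlier step, which stayed within the scatter and lay on the other aromatic ring, did not show that a change at this position could weaken inhibition, and the true size of this step cannot be read from a limit.

Two groups at this position cannot tell whether losing the bromine or adding the three methoxy groups matters more. A phenyl ring carrying a single methoxy group or a dimethylamino group would help separate these possibilities, and the data shown do not settle how either would behave.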